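A few compounds are considered here, and "the series" means these few. Any claim that something is new, unique, unknown or untested is made for them only; others in the source may bear on it.

Compound 3 `O=[N+]([O-])c1cc2c(O)c(-c3cc(F)cc(F)c3)c(O)nc2cc1Cl` gives 172 nM in an assay on isolated protein for inhibition of fatty acid synthase (Rattus norvegicus); on this read-out higher numbers stand for weaker inhibition and lower numbers for stronger inhibition. Among the three compounds measured it stands second highest: compound 2 `O=[N+]([O-])c1cc2c(O)c(-c3cc(Cl)cc(Cl)c3)c(O)nc2cc1Cl` gives 134 nM, and a 1.3-fold higher number from compound 2 to compound 3 (0.11 log units; within the scatter); compound 1 `O=[N+]([O-])c1cc2c(O)c(-c3ccc(Cl)cc3Cl)c(O)nc2cc1Cl` gives 443 nM, and a 2.6-fold lower number from compound 1 to compound 3 (0.41 log units; beyond the scatter). Compound 4 `O=[N+]([O-])c1cc2c(O)c(-c3nn[nH]n3)c(O)nc2cc1Cl` carries 2H-tetrazol-5-yl in place of 3,5-difluorophenyl on an aromatic carbon. For the measured compounds named here, none of the measured steps exchanges the aryl group for a small nitrogen-rich ring: a 3.3-fold lower number from compound 1 to compound 2 (0.52 log units; beyond the scatter) and a 2.6-fold lower number from compound 1 to compound 3 (0.41 log units; beyond the scatter) only move halogens around a phenyl ring, and a 1.3-fold higher number from compound 2 to compound 3 (0.11 log units; within the scatter) swaps one halogen for another. These steps offer no firm footing for so different a change, so the expectation is wide and leans toward a weaker result. Compound 4 is expected to give 700 nM in this assay, between 120 nM and 4000 nM, which would mean a 4.1-fold higher number from compound 3 to compound 4 (0.61 log units; beyond the scatter).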

Compound 4, half-maximal inhibitory concentration: 2600 nM
Compound 4: middle estimate off by 3.7-fold (0.57 log units), on the low side, and the stated range covers the measured number.
By their numbers in this assay, from the lowest: compounds 2 and 3 (each within the scatter of the next); then compound 1; then compound 4.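

In this assay, replacing the halogenated phenyl group with 2H-tetrazol-5-yl costs far more than any change among the phenyl groups: a 15-fold higher number from compound 3 to compound 4 (1.18 log units; beyond the scatter) and a 19-fold higher number from compound 2 to compound 4 (1.29 log units; beyond the scatter) are both large steps. Even the 2,4-dichlorophenyl compound lies below it, with a 5.9-fold higher number from compound 1 to compound 4 (0.77 log units; beyond the scatter) as a modest step. No measurement shown explains this loss. The compounds leave open whether unsubstituted phenyl or a carboxylic acid on this carbon would give numbers closer to the phenyl compounds or to compound 4.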